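The compounds below may be only part of what the source reports. "The series", "measured", "known", "first", "only" and "open" are said of these compounds alone.

Compound 1 `CC(C)OC(=O)N1CCC(Oc2ncnc3c2CCN3c2ccc(C#N)cc2F)CC1`: 63.1 nM
Compound 2 `CCCOC(=O)N1CCC(Oc2ncnc3c2CCN3c2ccc(S(C)(=O)=O)cc2F)CC1`: 79.4 nM
Compound 3 `CC(C)OC(=O)N1CCC(Oc2ncnc3c2CCN3c2ccc(S(C)(=O)=O)cn2)CC1`: 126 nM

In a functional assay on CHO-K1 cells for agonist activity at Glucose-dependent insulinotropic receptor (Homo sapiens), read by a luciferase reporter, with a stated time of 5 h (on this read-out higher numbers stand for an effect only at larger amounts of compound and lower numbers for an effect already at smaller amounts), compound 3 gives the highest of the three numbers, yet its gaps to compound 2 and to compound 1 both lie within the scatter, so the three compounds cannot be ranked. Compound 4 `Cc1ncccc1N1CCc2c(OC3CCN(C(=O)OC(C)C)CC3)ncnc21` differs from compound 3 by 2-methylpyridin-3-yl in place of 5-(methylsulfonyl)pyridin-2-yl on a nitrogen on an aromatic ring in a ring. Among the compounds with values here, the only measured step at this nitrogen, a 2.0-fold higher number from compound 1 to compound 3 (0.30 log units; within the scatter), also exchanged the aryl group and stayed within the scatter; no measured step matches the present change, so the data give little guidance. A step of a 1.6-fold higher number from compound 3 to compound 4 (0.20 log units; within the scatter) is therefore expected, with a lean toward a somewhat higher number. Compound 4 is estimated at 200 nM, within a range of 60 nM to 800 nM.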

Compound 4, half-maximal effective concentration: > 10000 nM
Compound 4 was reported as a limit; the forecaster's own chance of this, stated with the estimate: 10%; middle value at least 50-fold (1.69 log units) from the limit.
By their numbers in this assay, from the lowest: compounds 1, 2 and 3 (each within the scatter of the next). At a limit, above all of these: compound 4.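

Compound 4 is reported only as a limit of the assay, not as a number: the limit of > 10000 nM in this assay, at which 1 of the 4 values shown sits. The earlier exchange at this nitrogen, a 2.0-fold higher number from compound 1 to compound 3 (0.30 log units; within the scatter), had shown no change beyond the scatter, whereas 2-methylpyridin-3-yl gives an at least 79-fold higher number from compound 3 to compound 4 (1.89 log units; beyond the scatter) and an at least 150-fold higher number from compound 1 to compound 4 (2.19 log units; beyond the scatter). The aryl group on this nitrogen can therefore decide the read-out, and not every pyridine ring is tolerated there.

The compounds shown leave open whether the methyl on the ring, the ring's attachment, or the absence of methylsulfonyl or nitrile accounts for this. A plain pyridin-3-yl, or one carrying methylsulfonyl, would separate these.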